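Acetyl-to-hydrogen step on two cores

The source may hold more compounds than are shown below. What is called first, only, known or untested is meant among the compounds shown, and "the series" means these compounds.

Compound 1 `CC(=O)OC(C)n1cnc2c(Cl)nc(I)nc21` and compound 2 `CC(O)n1cnc2c(Cl)nc(I)nc21` share one core and differ by hydrogen in place of acetyl on an oxygen on a saturated carbon. In a functional assay (Homo sapiens) for inhibition (on this read-out higher numbers stand for weaker inhibition and lower numbers for stronger inhibition), compound 1 gives 14500 nM. For compound 2 the this assay reports only a limit, > 500000 nM. The step of an at least 34-fold higher number from compound 1 to compound 2 (1.53 log units; beyond the scatter) runs toward weaker inhibition, and its size is bounded only by the limit of > 500000 nM in this assay, at which 2 of the 3 values shown sit.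

Compound 3 `CC(=O)OC(C)n1cnc2c(S)nc(F)nc21` carries the acetyl as compound 1 does; the difference between the two cores is not broken down here. For compound 3 the this assay again reports only a limit, > 500000 nM.

Compound 4 `CC(O)n1cnc2c(S)nc(F)nc21` is still to be measured. It differs from compound 3 by hydrogen in place of acetyl on an oxygen on a saturated carbon, the same kind of change as from compound 1 to compound 2, the place being worded alike in both cases. For compound 4 the expected step is a step that the limit leaves unreadable from compound 3 to compound 4, set beside the measured at least 34-fold higher number from compound 1 to compound 2 (1.53 log units; beyond the scatter). This rests on compound 3 already sitting at the limit of > 500000 nM in this assay, at which 2 of the 3 values shown sit, and on the direction of an at least 34-fold higher number from compound 1 to compound 2 (1.53 log units; beyond the scatter). Compound 4 is estimated at 1000000 nM, most likely reported by the this assay only as a limit.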

Compound 4, half-maximal inhibitory concentration: > 500000 nM
Compound 4 ended at the assay's limit; the forecaster's own chance of this, stated with the estimate: 90%; the middle value lies beyond the limit too.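

In this assay compound 4 gives > 500000 nM as a limit. Compound 3 also stands only at a limit, so no step can be read between compound 3 and compound 4: the limit of > 500000 nM in this assay, at which 3 of the 4 values shown sit. The compounds shown leave open whether replacing acetyl with hydrogen changes inhibition on the core of compound 3.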